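This account rests on a few compounds, and the source may have more. Where it says the series, first, only, none or still open, it means among the compounds named here.

Working notes on the series. Compound 1 `COc1cc(-c2nn(-c3ccc(NC(=O)Nc4ccc(Cl)c(C(F)(F)F)c4)cc3)cc2-c2ccncc2)ccc1Cl` gives 14000 nM in a functional assay on A375P cells (Homo sapiens) for antiproliferative activity, read by MTT assay, with a stated time of 48 h; a higher number here means a weaker inhibitor, a lower number a stronger inhibitor. Compound 2 `O=C(Nc1ccc(-n2cc(-c3ccncc3)c(-c3ccc(Cl)c(O)c3)n2)cc1)Nc1cccc(Cl)c1Cl` gives 16800 nM in this assay, and compound 3 `O=C(Nc1ccc(-n2cc(-c3ccncc3)c(-c3ccc(Cl)c(O)c3)n2)cc1)Nc1ccc(Cl)c(Cl)c1` gives 13500 nM in this assay. For the measured compounds named here, the one measured step, a 1.2-fold lower number from compound 2 to compound 3 (0.09 log units; within the scatter), stays within the scatter. Compound 3 holds the lowest of the three numbers, but compound 1 and compound 2 both sit within the scatter of it, so no order can be read among the three.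

Compound 4 `O=C(Nc1ccc(-n2cc(-c3ccncc3)c(-c3ccc(Cl)c(O)c3)n2)cc1)Nc1ccc(Cl)c(C(F)(F)F)c1` differs from compound 3 by trifluoromethyl in place of chloro on an aromatic carbon. Going by the values given here, no measured step exchanges chloro for trifluoromethyl on this ring, so nothing bears on it directly; the step from compound 2 to compound 3 only moves the chloro pattern on the group at the amide-type nitrogen and stays within the scatter. Compound 1 already carries the 4-chloro-3-(trifluoromethyl)phenyl group on a core that differs elsewhere, and its value lies within the scatter of the value of compound 3. The step of a 1.0-fold lower number from compound 3 to compound 4 (0.02 log units; within the scatter) is therefore expected to be none beyond the scatter. Compound 4 is estimated at 13000 nM, with a range from 6000 nM to 28000 nM.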

Compound 4, half-maximal inhibitory concentration: 14900 nM
Compound 4: middle estimate off by 1.1-fold (0.06 log units), on the low side, and the stated range covers the measured number.
By their numbers in this assay, from the lowest: compounds 3, 1, 4 and 2 (each within the scatter of the next).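

In this assay, trifluoromethyl in place of chloro on this aromatic carbon, ortho to a chloro group, gives a 1.1-fold higher number from compound 3 to compound 4 (0.04 log units; within the scatter), so this first direct reading of the exchange shows that the larger group leaves the number within the scatter. Changing the whole group on the amide-type nitrogen, 4-chloro-3-(trifluoromethyl)phenyl in place of 2,3-dichlorophenyl, gives a 1.1-fold lower number from compound 2 to compound 4 (0.05 log units; within the scatter), and hydrogen in place of methyl on the oxygen gives a 1.1-fold higher number from compound 1 to compound 4 (0.03 log units; within the scatter), so neither change separates the compounds in this assay. For the compounds shown here, no evidence on these compounds accompanies the result.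

Going by these compounds, whether any group at this aromatic carbon moves the number beyond the scatter remains open, and an amine, a nitrile or a carboxylic acid there would test it. On these data alone, whether a longer chain on the oxygen does so also remains open.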